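This account rests on a few compounds, and the source may have more. Where it says the series, first, only, none or still open, it means among the compounds named here.

Measured compounds:
compound 1, `CN(C)C(=O)c1cc2cnc(Nc3ccc(S(=O)(=O)NCCCCN=C=S)cc3)nc2n1C1CCCC1`, 101%
compound 2, `CN(C)C(=O)c1cc2cnc(Nc3ccc(C(=O)NCCCCCN=C=S)cc3F)nc2n1C1CCCC1`, 15.6%
compound 3, `CN(C)C(=O)c1cc2cnc(Nc3ccc(C(=O)NCCCCCCN=C=S)cc3F)nc2n1C1CCCC1`, 22.9%

In a functional assay on A549 cells (Homo sapiens) for inhibition, read by CCK-8 assay, with a stated time of 72 h, tested at 10 uM (a lower number here means a weaker effect, a higher number a stronger effect of the compound at the concentration tested), compound 1 gives 101%, the highest of the three numbers; compound 3 stands nearest and compound 2 furthest, both lower by amounts beyond the scatter. The unmeasured compound 4 is `CN(C)C(=O)c1cc2cnc(Nc3ccc(N=C=S)cc3)nc2n1C1CCCC1`. It differs from compound 1 by a group of 3 heavy atoms (1 carbon, 1 nitrogen, 1 sulfur; no ring) in place of a group of 11 heavy atoms (5 carbon, 2 nitrogen, 2 oxygen, 2 sulfur; no ring), on an aromatic carbon. For the measured compounds named here, only one measured step exists, from compound 2 to compound 3: a number 7.3 percentage points higher from compound 2 to compound 3 (within the scatter). That step lengthens the chain carrying the isothiocyanate while keeping the end group, and it lies within the scatter, so for those two compounds the chain length made no visible difference. Going by the values given here, the change to compound 4 is of another kind, since it removes the sulfonamide and the whole chain and leaves the isothiocyanate directly on the aromatic carbon, and no measured pair covers such a removal. The estimate therefore rests on compound 1 alone, with a wide allowance downward. For compound 4 the expected step is a number 31 percentage points lower from compound 1 to compound 4 (beyond the scatter). Compound 4 is expected to give 70%, within 30% to 100%.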

Compound 4, a percentage reported as inhibition, at one concentration (the size of the read-out at that concentration, not a potency): 97.9%
Beside the measured number, compound 4's estimate is 27.9 percentage points below it, within the range that was stated.
By their numbers in this assay, from the lowest: compounds 2 and 3 (each within the scatter of the next); then compounds 4 and 1 (each within the scatter of the next).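

In this assay, putting the group of 3 heavy atoms in place of the group of 11 heavy atoms on this aromatic carbon, para to a large group, gives a number 3.1 percentage points lower from compound 1 to compound 4 (within the scatter) and so leaves the read-out unchanged within the scatter. At this position and this single concentration, the sulfonamide and the chain of compound 1 are therefore not needed to keep the effect, and an isothiocyanate sitting directly on the aromatic carbon suffices. No measurement shown explains this result.

As far as these compounds go, how an amine on this aromatic carbon would read in place of the isothiocyanate remains open, so the part played by the isothiocyanate itself is untested here. Because the read-out at one concentration is not a potency, whether compound 1 and compound 4 would also stay together at lower concentrations is open too.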